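Methyl on the sulfur ring: from compound 3 to compound 4

The compounds below may be only part of what the source reports. "The series", "measured", "known", "first", "only" and "open" are said of these compounds alone.

Compound 1, `c1ccc(-c2cnco2)c(NCC2=NCCN2)c1`: 17.4 nM
Compound 2, `c1coc(-c2ccccc2NCC2=NCCN2)c1`: 0.468 nM
Compound 3, `c1csc(-c2ccccc2NCC2=NCCN2)c1`: 2.24 nM

All three compounds share the same core and differ only in the five-membered ring attached to it. In a functional assay for activation of Alpha-1A adrenergic receptor (Homo sapiens), read by calcium flux (a lower number here means that less compound is needed, a higher number that more compound is needed for the effect), compound 3 stands second highest of the three numbers: it sits between compound 2, with a 4.8-fold higher number from compound 2 to compound 3 (0.68 log units; beyond the scatter), and compound 1, with a 7.8-fold lower number from compound 1 to compound 3 (0.89 log units; beyond the scatter). The change a 37-fold lower number from compound 1 to compound 2 (1.57 log units; beyond the scatter) was the largest seen.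

Compound 4, `Cc1ccsc1-c1ccccc1NCC1=NCCN1`, differs from compound 3 by methyl in place of hydrogen on an aromatic carbon. Going by the values given here, none of the measured steps touches a methyl; each of them swaps one five-membered ring for another. They show that the ring itself shifts the number, but give no guide to a single added carbon on it. The expectation is therefore a step of a 1.1-fold higher number from compound 3 to compound 4 (0.05 log units; within the scatter), which lies within the scatter. Compound 4 is estimated at 2.5 nM in this assay, with a likely range from 0.8 nM to 8 nM.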

Compound 4, half-maximal effective concentration: 0.851 nM
The estimate for compound 4 lay 2.9-fold (0.47 log units) above the measured number, and the stated range covers the measured number.
By their numbers in this assay, from the lowest: compounds 2 and 4 (each within the scatter of the next); then compound 3; then compound 1.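

In this assay, going by these compounds alone, the earlier steps only exchanged one five-membered ring for another; this one shows that a single methyl on the aromatic carbon next to the ring atom that bears a large group also moves the number (a 2.6-fold lower number from compound 3 to compound 4 (0.42 log units; beyond the scatter)). With that methyl, the 3-methylthiophen-2-yl group can no longer be told apart from furan-2-yl (a 1.8-fold higher number from compound 2 to compound 4 (0.26 log units; within the scatter)), while the gap to 1,3-oxazol-5-yl stays large (a 20-fold lower number from compound 1 to compound 4 (1.31 log units; beyond the scatter)). Nothing available explains why the added methyl shifts the number.

Going by these compounds, it remains open whether a methyl on the furan-2-yl ring of compound 2 would shift the number in the same way. How an ethyl group, a methoxy group or an amine would behave on this same carbon is also unknown.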